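This account rests on a few compounds, and the source may have more. Where it says the series, first, only, none or still open, it means among the compounds named here.

Compound 2 `Nc1scc(CN2CCN(c3ccc(F)cc3Cl)CC2)c1C(=O)c1ccc(Cl)cc1` stands level with compound 1 `Nc1scc(CN2CCN(c3ccc(Cl)cc3Cl)CC2)c1C(=O)c1ccc(Cl)cc1` and compound 3 `Nc1scc(CN2CCN(C3CCCCCC3)CC2)c1C(=O)c1ccc(Cl)cc1` in an assay on CHO cells for displacement of a labelled ligand from adenosine receptor A1 (Homo sapiens), read by scintillation counting, with a stated time of 120 min, tested at 10 uM; a higher number here means more inhibition at the concentration tested (going by the name of the read-out), a lower number less inhibition: compound 2 gives 0%, compound 1 gives 0% and compound 3 gives 0%, so nothing among the three separates within the scatter. Compound 4 `Nc1scc(CN2CCN(c3ccc(F)cc3F)CC2)c1C(=O)c1ccc(Cl)cc1` differs from compound 2 by fluoro in place of chloro on an aromatic carbon. Going by the values given here, the one step that bears directly on this change is no change at the digits printed from compound 1 to compound 2 (within the scatter), the same exchange of a halogen on the aromatic ring; the steps of no change at the digits printed from compound 1 to compound 3 (within the scatter) and no change at the digits printed from compound 2 to compound 3 (within the scatter) replace the whole ring on the amine nitrogen and are equally flat. The analyst therefore expects no step beyond the scatter, no change at the digits printed from compound 2 to compound 4 (within the scatter). Compound 4 is expected to give 0%, within -5% to 10%.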

Compound 4, a percentage reported as inhibition, at one concentration (the size of the read-out at that concentration, not a potency): 1%
Estimate against measurement, compound 4: 1 percentage points below, and the stated range covers the measured number.
By their numbers in this assay, from the lowest: compounds 1, 2, 3 and 4 (each within the scatter of the next).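

Fluoro in place of chloro on the aromatic carbon ortho to a large group gives a number 1 percentage points higher from compound 2 to compound 4 (within the scatter) in this assay, so this halogen place reads as flat as the one changed in the step to compound 2. Changing both halogens gives a number 1 percentage points higher from compound 1 to compound 4 (within the scatter) and changing the whole group on the ring nitrogen gives a number 1 percentage points higher from compound 3 to compound 4 (within the scatter), so neither wider exchange separates the compounds. Nothing available explains this flat reading.

From the compounds shown here alone, whether a carboxylic acid or a methoxy group at this place would give any larger reading in this assay stays open.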